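Swapping the amino acid side chain on the quinone nitrogen

The compounds below may be only part of what the source reports. "The series", "measured", "known", "first", "only" and "open" are said of these compounds alone.

Compound 1: `CC1=CCC[C@H]2[C@](C)(CC3=CC(=O)C=C(N[C@@H](C(=O)O)C(C)C)C3=O)[C@@H](C)CC[C@]12C` — 7780 nM
Compound 2: `CC(C)[C@@H](NC1=CC(=O)C=C(C(C)(C)C)C1=O)C(=O)O` — 57800 nM

Of the compounds shown here, two have been tested in a functional assay on K562 cells (Homo sapiens) for cytotoxicity, read by MTT assay, with a stated time of 72 h; a lower number here means a stronger inhibitor, a higher number a weaker inhibitor. Compound 1 gives 7780 nM, and compound 2 gives 57800 nM. Compound 1 therefore stands as the lowest of the two numbers, and the gap to compound 2 lies beyond the usual scatter of this assay. For the measured compounds named here, no single-change step between the two measured compounds is available, so what their values show is only that compound 1 carries the terpene portion and compound 2 a tert-butyl group in its place, with compound 1 the stronger of the pair.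

The unmeasured compound 3 is `CSCC[C@H](NC1=CC(=O)C=C(C[C@]2(C)[C@@H](C)CC[C@]3(C)C(C)=CCC[C@@H]23)C1=O)C(=O)O`. Its change from compound 1 is 1-carboxy-3-(methylsulfanyl)propyl in place of 1-carboxy-2-methylpropyl on an amine nitrogen. The terpene portion and the shared core stay untouched; only the amino acid attached to the nitrogen differs.

Going by the values given here, with no measured step of this kind available, the expected step from compound 1 to compound 3 in this assay is a 1.0-fold higher number from compound 1 to compound 3 (0.01 log units; within the scatter), that is, no change beyond the scatter. Compound 3 is therefore estimated at 8000 nM, within a range of 3000 nM to 25000 nM.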

Compound 3, half-maximal inhibitory concentration: 13600 nM
Compound 3: middle estimate off by 1.7-fold (0.23 log units), on the low side; the range from low to high includes it.
By their numbers in this assay, from the lowest: compounds 1 and 3 (each within the scatter of the next); then compound 2.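

In this assay, for the compounds shown here, the step of a 1.7-fold higher number from compound 1 to compound 3 (0.24 log units; within the scatter) is the first measured single change at this position, an amine nitrogen whose other neighbour is a double-bonded ring carbon. It shows that, with the terpene portion and the shared core held constant, this pair of amino acid groups cannot be told apart in this cell read-out, even though the entering 1-carboxy-3-(methylsulfanyl)propyl group adds a sulfur atom that the leaving 1-carboxy-2-methylpropyl group lacks. Nothing available gives a reason for this result, and one pair alone cannot show how other groups would behave at this nitrogen.

Both groups here keep the carboxylic acid, so the compounds shown leave open what happens when a methyl ester or a primary amide takes its place. They also leave open how the same position would read with a side chain ending in an amine, or with one carrying a phenyl ring.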